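A few compounds are considered here, and "the series" means these few. Any claim that something is new, unique, unknown or untested is made for them only; others in the source may bear on it.

Measured compounds:
- compound 1 `CCCCCCCCOc1nc(N)nc2c1ncn2/C=C1/CC1(CO)CO`: > 20000 nM
- compound 2 `CN(C)c1nc(N)nc2c1ncn2/C=C1/CC1(CO)CO`: > 20000 nM
- compound 3 `Nc1nc(N2CCCC2)c2ncn(/C=C3/CC3(CO)CO)c2n1`: > 20000 nM

In an ADME assay on BCBL1 cells (Homo sapiens) for cytotoxicity, with a stated time of 7 days (on this read-out lower numbers stand for higher toxicity in this test and higher numbers for lower toxicity in this test), compound 1 gives > 20000 nM, which is a limit of the assay and not a number. Compound 2 and compound 3 stand at that same limit, so compound 1 cannot be ranked against them.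

Compound 4 `CCCNc1nc(N)nc2c1ncn2/C=C1/CC1(CO)CO` swaps one group on the shared core: propylamino in place of octyloxy on an aromatic carbon.

The closest measured changes also replace octyloxy on that carbon: a step that the two limits leave unreadable from compound 1 to compound 2 and a step that the two limits leave unreadable from compound 1 to compound 3. The swap between the two amino groups gives a step that the two limits leave unreadable from compound 2 to compound 3. None of these steps has a readable size. The pattern that does exist is the limit of > 20000 nM in this assay, at which 3 of the 3 values shown sit, so no step beyond the scatter is expected in this assay, and compound 4 will probably also report only a limit.

The estimated step is a step that the limit leaves unreadable from compound 1 to compound 4.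

The expected value for compound 4 is 25000 nM, with an estimated range of 10000 nM to 60000 nM.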

Compound 4, half-maximal cytotoxic concentration: > 20000 nM
Compound 4 gave a limit, no number; the forecaster's own chance of this, stated with the estimate: 85%; the middle value is on the limit's open side.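

Among these compounds, compound 4, like compound 1, compound 2 and compound 3, reports only a limit, and no step between them can be read. The compounds shown leave open how far apart these four truly lie in this assay.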